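Ring stereochemistry and liver half-life in a hydroxyproline dipeptide

The source may report more compounds than this note shows. Statements on the series, on what has been measured and on what is new or still open speak of the compounds shown alone.

The series is a set of stereoisomers of one hydroxyproline-serine dipeptide core, compared in an ADME assay on liver (Mus musculus, strain C57BL/6) for metabolic stability, read by HPLC, with a stated time of 12 h; a higher number here means that the compound lasts longer, a lower number that the compound disappears faster. Compound 1 `O=C(O)[C@H](CO)NC(=O)[C@H]1C[C@H](O)CN1` reaches the assay limit of > 12 h. Compound 2 `O=C(O)[C@@H](CO)NC(=O)[C@H]1C[C@@H](O)CN1` likewise sits at the limit of > 12 h, so only a lower bound is known for it, and it shares that bound with compound 1 (the limit of > 12 h in this assay, at which 2 of the 3 values shown sit). Compound 3 `O=C(O)[C@H](CO)NC(=O)[C@@H]1C[C@H](O)CN1` gives 0.51 h, and the steps of an at least 23-fold lower number from compound 1 to compound 3 (1.37 log units; beyond the scatter) and an at least 23-fold lower number from compound 2 to compound 3 (1.37 log units; beyond the scatter) are both large, which rests on the fact that compounds 1 and 3 differ only in the configuration as drawn and (the fact that compounds 2 and 3 differ only in the configuration as drawn); the step that the two limits leave unreadable from compound 1 to compound 2 cannot be sized because both ends are limits (the fact that compounds 1 and 2 differ only in the configuration as drawn).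

Compound 4 `O=C(O)[C@H](CO)NC(=O)[C@@H]1C[C@@H](O)CN1` is the remaining isomer: the two compounds have the same atoms and bonds and differ only in configuration as drawn: 2 of 3 stereo elements differ; a stereocentre at a saturated chain carbon is drawn R in compound 2 and S in compound 4; a stereocentre at a saturated ring carbon is drawn R in compound 2 and S in compound 4. The measured steps show that inversion at a saturated ring carbon of this core can cut the half-life from the limit down to well under an hour, as seen from compound 1 to compound 3 and from compound 2 to compound 3. Since compound 4 also carries an inverted saturated ring carbon relative to compound 2, a large downward step is expected in this assay, with the estimated step of an at least 17-fold lower number from compound 2 to compound 4 (1.23 log units; beyond the scatter). The half-life of compound 4 is therefore estimated at 0.7 h, in the range 0.2 h to 3 h.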

Compound 4, half-life: 0.27 h
The estimate for compound 4 lay 2.6-fold (0.41 log units) above the measured number, and the stated range covers the measured number.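

In this assay, for the compounds shown here, compound 4 gives the first pair in which both values can be read and only one ring carbon differs, and the result is a 1.9-fold lower number from compound 3 to compound 4 (0.28 log units; within the scatter), so inverting this ring carbon leaves no change that can be told from scatter: the fact that compounds 3 and 4 differ only in the configuration as drawn. A short half-life is therefore not tied to one drawing of this carbon, since compound 3 and compound 4 both stay far from the limit reached by the other two compounds, and it goes with the drawing of the other ring carbon, which these two share. The new compound also gives an at least 44-fold lower number from compound 2 to compound 4 (1.64 log units; beyond the scatter) and an at least 44-fold lower number from compound 1 to compound 4 (1.64 log units; beyond the scatter), the latter with the saturated chain carbon unchanged and both ring carbons inverted: the fact that compounds 1 and 4 differ only in the configuration as drawn.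

The step between compound 1 and compound 2 cannot be read because both sit at a limit, and no pair shown differs at the saturated chain carbon alone, so the share of that carbon stays open: the fact that compounds 1 and 2 differ only in the configuration as drawn. Going by these compounds, it also remains open whether this ring-carbon pattern would hold with a methyl ester in place of the carboxylic acid or a fluorine in place of the ring hydroxyl.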